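A few compounds are considered here, and "the series" means these few. Any claim that something is new, unique, unknown or untested is made for them only; others in the source may bear on it.

Working notes on the cyanophenylamino series in an ADME assay on MT4 cells (Homo sapiens) for cytotoxicity, read by MTT assay, with a stated time of 5 days; on this read-out lower numbers stand for higher toxicity in this test and higher numbers for lower toxicity in this test.

Of the compounds shown here, three have numbers so far. Compound 1 `N#Cc1ccc(Nc2nccc(NCc3ccccn3)n2)cc1` gives 8500 nM. Compound 2 `N#Cc1ccc(Nc2nccc(OCc3cccc(F)c3)n2)cc1` gives 105000 nM. Compound 3 `N#Cc1ccc(Nc2nccc(OCc3ccccc3C(F)(F)F)n2)cc1` gives 173000 nM. On these three numbers compound 2 stands second highest: its nearest neighbour is compound 3, whose number lies within the scatter of it, so no order between the two can be read; the furthest is compound 1, whose number lies beyond the scatter on the lower side.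

Compound 4 `N#Cc1ccc(Nc2nccc(OCc3cccc(C#N)c3)n2)cc1` is the next point. It differs from compound 2 in one place: cyano in place of fluoro on an aromatic carbon. Fluoro leaves and cyano enters on an aromatic carbon of the six-membered carbon-only ring, meta to a large group; cut one bond further out, the change reads 3-fluorophenyl to 3-cyanophenyl.

For the measured compounds named here, no step between measured compounds is available that would show how such an exchange moves this assay. Going by the values given here, the two benzyl ether compounds, compound 2 and compound 3, sit within the scatter of each other, and that is the only guide. The expected step of a 1.0-fold higher number from compound 2 to compound 4 (0.02 log units; within the scatter) is therefore none beyond the scatter, in no preferred direction. Compound 4 is estimated at 110000 nM, with a range from 40000 nM to 300000 nM.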

Compound 4, half-maximal cytotoxic concentration: 4100 nM
For compound 4 the middle estimate is 27-fold (1.43 log units) above the measured one, outside the stated range (below it).
By their numbers in this assay, from the lowest: compound 4; then compound 1; then compounds 2 and 3 (each within the scatter of the next).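

In this assay, cyano in place of fluoro on an aromatic carbon, meta to a large group, gives a 26-fold lower number from compound 2 to compound 4 (1.41 log units; beyond the scatter) and so counts as a large step. For the compounds shown here, the earlier compounds offered no step in a single place, so this is the first sign that one exchange at this carbon can move the number well beyond the scatter. Nothing at hand bears on what lies behind this step.

From the compounds shown here alone, whether the step belongs to the nitrile specifically or would also appear with other groups stays open; an amine, a carboxylic acid or a methoxy group on the same carbon would help to settle that. Also open, going by these compounds, is whether cyano gives a step of this size elsewhere on the ring, or with the core of compound 1 in place of the ether.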